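Aryl variation on the double-bonded chain of the shared core

This account rests on a few compounds, and the source may have more. Where it says the series, first, only, none or still open, it means among the compounds named here.

Measured compounds:
compound 1, `COc1ccc(/C=C/C(=O)c2ccc(OC)c3c2OC(C)(C)C=C3)c(F)c1`: 6570 nM
compound 2, `COc1ccc(C(=O)/C=C/c2cccc(F)c2)c2c1C=CC(C)(C)O2`: a limit, > 10000 nM
compound 3, `COc1ccc(C(=O)/C=C/c2ccc(N(C)C)cc2)c2c1C=CC(C)(C)O2`: 570 nM

In a functional assay on SW-620 cells (Homo sapiens) for antiproliferative activity, read by MTT assay, with a stated time of 24 h (a lower number here means a stronger inhibitor, a higher number a weaker inhibitor), compound 3 gives 570 nM, the lowest of the two numbers in hand; compound 1 stands at 6570 nM. Compound 2 returns only a limit, > 10000 nM (the limit of > 10000 nM in this assay, at which 1 of the 3 values shown sits). The two aryl swaps toward compound 3 are both large, a 12-fold lower number from compound 1 to compound 3 (1.06 log units; beyond the scatter) and an at least 17-fold lower number from compound 2 to compound 3 (1.24 log units; beyond the scatter), whereas an at least 1.5-fold higher number from compound 1 to compound 2 (0.18 log units; that floor lies within the scatter) rests on a floor that lies within the scatter.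

Compound 4, `COc1ccc(C(=O)/C=C/c2ccc(-n3ccnc3)cc2)c2c1C=CC(C)(C)O2`, changes the group on the aryl ring of compound 3: 1H-imidazol-1-yl in place of dimethylamino on an aromatic carbon. For the measured compounds named here, no measured step removes the dimethylamino group; the measured steps only show that the 4-(dimethylamino)phenyl group carries the much lower number relative to the two fluorinated aryls. From the compounds shown here alone, the 1H-imidazol-1-yl group is untested here, so part of that gain is expected to be given back. Compound 4 is therefore expected at 1500 nM, with a range of 500 nM to 5000 nM. The expected step is a 2.6-fold higher number from compound 3 to compound 4 (0.42 log units; beyond the scatter).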

Compound 4, half-maximal inhibitory concentration: > 10000 nM
Compound 4 gave a limit, no number; the forecaster's own chance of this, stated with the estimate: 10%; at least 6.6-fold (0.82 log units) between middle value and limit.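

Exchanging dimethylamino for 1H-imidazol-1-yl on the same aromatic carbon, para to a large group, gives an at least 17-fold higher number from compound 3 to compound 4 (1.24 log units; beyond the scatter) in this assay. The low number of compound 3 therefore depends on the group at this place, and a nitrogen-linked group there is not enough in itself: compound 3 and compound 4 both attach through nitrogen, yet only compound 3 keeps a low number. Compound 4 carries a limit and not a number, so the full size of the loss stays unfixed, and it now sits at the same limit as compound 2: the limit of > 10000 nM in this assay, at which 2 of the 4 values shown sit.

From the compounds shown here alone, whether a smaller amine such as methylamino, or a cyclic amine such as pyrrolidin-1-yl or morpholin-4-yl, would keep the number of compound 3 remains open. Equally open, going by these compounds, is how an unsubstituted phenyl would compare with the 4-(dimethylamino)phenyl group.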